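A few compounds are considered here, and "the series" means these few. Any claim that something is new, unique, unknown or untested is made for them only; others in the source may bear on it.

Compound 2 `CCC1=C(O)c2c(oc(-c3ccc(CBr)cc3)cc2=O)C(CC)(CC)C1=O` stands at a limit in a functional assay on KB cells (Homo sapiens) for antiproliferative activity, read by sulforhodamine B assay, with a stated time of 3 days; a lower number here means that less compound is needed, a higher number that more compound is needed for the effect: compound 2 gives > 46.5 uM, a limit of the assay rather than a number. Going by the values given here, compound 1 `CCCOc1ccc(-c2cc(=O)c3c(o2)C(CC)(CC)C(=O)C(CC)=C3O)cc1` is the only other measured member of the series. In this assay compound 1 gives > 50.5 uM, again a limit and not a number. Both ends sit at limits, the limit of > 50.5 uM in this assay, at which 1 of the 2 values shown sits, and (the limit of > 46.5 uM in this assay, at which 1 of the 2 values shown sits), so the step that the two limits leave unreadable from compound 1 to compound 2 is not readable. Compound 3 `CCC1=C(O)c2c(oc(-c3cc(C)ccc3C)cc2=O)C(CC)(CC)C1=O` differs from compound 2 by 2,5-dimethylphenyl in place of 4-(bromomethyl)phenyl on an aromatic carbon. Among the compounds with values here, no measured step bears on this change, and the only measured step is itself unreadable. No step beyond the scatter is therefore expected for compound 3 in this assay, and the expected step that the limit leaves unreadable from compound 2 to compound 3 is small. Compound 3 is estimated at 50 uM, within a range from 15 uM to 150 uM, with the most likely outcome that the assay again reports only a limit.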

Compound 3, concentration for half-maximal effect: 14.5 uM
The estimate for compound 3 lay 3.4-fold (0.54 log units) above the measured number; the measured number lies below the stated range.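

In this assay, the aromatic carbon next to the ring oxygen now carries a change with a readable direction: 2,5-dimethylphenyl in place of 4-(bromomethyl)phenyl gives an at least 3.2-fold lower number from compound 2 to compound 3 (0.50 log units; beyond the scatter). The step between the two earlier compounds cannot be read, and the two groups here have the same heavy-atom count, so that count does not separate them. The size of the new step is only a bound because compound 2 stands at a limit: the limit of > 46.5 uM in this assay, at which 1 of the 3 values shown sits.

On these data alone, compound 3 changes the bromine and both methyl groups together, so it remains open which of these differences carries the step. Also open, as far as these compounds go, is how a phenyl with a single methyl, an aminomethyl or a carboxylic acid at this place would read in this assay.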